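This account rests on a few compounds, and the source may have more. Where it says the series, first, only, none or still open, it means among the compounds named here.

In a physicochemical assay for solubility, at pH 7.4 (a higher number here means a more soluble compound, a lower number a less soluble compound), three compounds built on a shared core have been measured so far. Compound 1 `Cc1cc(NC(=O)Nc2ccc(C(C)(C)C)cc2)c2ccccc2n1` gives 6200 nM, the highest of the three numbers. Compound 3 `COc1ccc(NC(=O)Nc2cc(C)nc3ccccc23)cc1Cl` gives 400 nM and compound 2 `Cc1cc(NC(=O)Nc2ccccc2C(C)(C)C)c2ccccc2n1` gives 100 nM, and both gaps down from compound 1 lie beyond the usual scatter. Compound 4 `Cc1cc(NC(=O)Nc2ccc(C(F)(F)F)cc2)c2ccccc2n1` has not yet been measured in this assay. It departs from compound 1 by a single exchange, trifluoromethyl in place of tert-butyl on an aromatic carbon, para to a large group: trifluoromethyl in place of tert-butyl on an aromatic carbon. Among the compounds with values here, no measured pair in this set shows that exchange, so the data offer no direct guide to its size. A modest fall is expected, one that may not clear the scatter, and the range is kept wide for that reason. The estimated step is a 2.1-fold lower number from compound 1 to compound 4 (0.32 log units; beyond the scatter). For compound 4 the estimate is 3000 nM, with an expected range from 800 nM to 11000 nM.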

Compound 4, solubility: 100 nM
Compound 4: middle estimate off by 30-fold (1.48 log units), on the high side; the whole stated range lies above it.
By their numbers in this assay, from the lowest: compounds 2 and 4 (each within the scatter of the next); then compound 3; then compound 1.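

In this assay, within the data shown here, the exchange of tert-butyl for trifluoromethyl on an aromatic carbon, para to a large group, gives a 62-fold lower number from compound 1 to compound 4 (1.79 log units; beyond the scatter) and is the first single change in this set that can be read. The step is large even though the two groups have the same heavy-atom count and neither carries a ring, a hydrogen-bond donor or acceptor, or a net charge, so this position is clearly sensitive to the choice between them. Nothing measured here accounts for the size of the step.

From the compounds shown here alone, with only these two groups compared at this position, it remains open whether the step reflects the loss of tert-butyl or the arrival of trifluoromethyl. Going by these compounds, how an amine or a carboxylic acid would fare at the same carbon also remains open.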